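This account rests on a few compounds, and the source may have more. Where it says the series, first, only, none or still open, it means among the compounds named here.

In a functional assay on MCF7 cells (Homo sapiens) for antiproliferative activity, read by MTT assay, with a stated time of 24 h (a higher number here means a weaker inhibitor, a lower number a stronger inhibitor), compound 1 (`CCCC(O)(C#Cc1ccc(C(CC)(CC)C2=CN(CC)C(C(=O)NCCN(CC)CC)C2)cc1C)CCC`) gives 1290 nM and compound 2 (`CCN(CC)CCNC(=O)C1CC(C(CC)(CC)c2ccc(C#CC(O)C3CCCCC3)c(C)c2)=CN1CC`) gives 3070 nM on the same scale. Compound 3 (`CCN(CC)CCNC(=O)C1CC=C(C(CC)(CC)c2ccc(C#CC(C)(O)CC)c(C)c2)N1CC`) gives 600 nM as the lowest of these three numbers. Compound 4 (`CCN(CC)CCNC(=O)C1CC=C(C(CC)(CC)c2ccc(/C=C/C(C)(O)CC)c(C)c2)N1CC`) changes compound 3 in one place, on an aromatic carbon, where the side chain trades its triple bond for a double bond: a group of 7 heavy atoms (6 carbon, 1 oxygen; no ring) in place of a group of 7 heavy atoms (6 carbon, 1 oxygen; no ring), on an aromatic carbon is the whole change. For the measured compounds named here, the one measured step is a 2.4-fold higher number from compound 1 to compound 2 (0.38 log units; beyond the scatter) on swapping the group on the triple-bonded carbon, and that swap left the triple bond in place. Going by the values given here, no measured pair compares the two bond types, so the guide is loose and no step beyond the scatter is expected. The expected step is a 1.3-fold higher number from compound 3 to compound 4 (0.12 log units; within the scatter) in size. Compound 4 is estimated at 800 nM with a range from 250 nM to 2500 nM for now.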

Compound 4, half-maximal inhibitory concentration: "not active" (no number reported)
The entry for compound 4 holds no number; no gap can be computed for the estimate.
By their numbers in this assay, from the lowest: compound 3; then compound 1; then compound 2.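

For the compounds shown here, compound 4 is reported only as "not active", with no number, so no step from compound 3 to compound 4 can be read. The size of any change on trading the triple bond for a double bond stays open, and nothing at hand explains the entry.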